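Moving bromine and carboxy around the benzyl ring

The compounds below may be only part of what the source reports. "The series", "measured", "known", "first", "only" and "open" are said of these compounds alone.

This account follows one change within a set of four compounds that share the same core and differ only in the substituted benzyl group. Compound 1 `CC#CCn1c(N2CCC[C@@H](N)C2)cc(=O)n(Cc2cccc(C(=O)O)c2Br)c1=O` and compound 3 `CC#CCn1c(N2CCC[C@@H](N)C2)cc(=O)n(Cc2cccc(C(=O)O)c2F)c1=O` have no result in an assay on isolated protein for inhibition of Dipeptidyl peptidase 9 (Homo sapiens), read by fluorescence, with stated times of 15 min and 20 min; on this read-out lower numbers stand for stronger inhibition and higher numbers for weaker inhibition: for compound 1 the entry reads "not determined" (no result reported), and for compound 3 it likewise reads "not determined" (no result reported). Going by the values given here, compound 2 `CC#CCn1c(N2CCC[C@@H](N)C2)cc(=O)n(Cc2cc(C(=O)O)ccc2Br)c1=O` is the only member with any reported result, and for compound 2 the entry in this assay is a limit of the assay, > 100 nM, not a number. So compound 3 stands without a single value, beside one limit and one further missing entry; the only guidance is the limit of > 100 nM in this assay, at which 1 of the 3 values shown sits.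

Compound 4 `CC#CCn1c(N2CCC[C@@H](N)C2)cc(=O)n(Cc2cc(Br)cc(C(=O)O)c2)c1=O` has not been measured. It differs from compound 3 by 3-bromo-5-carboxyphenyl in place of 3-carboxy-2-fluorophenyl on a saturated chain carbon bound to an aromatic nitrogen. Among the compounds with values here, no step between measured compounds is known here, so the size or direction of this change cannot be read from the data; the expectation is no movement beyond the scatter, with compound 4 likely to sit at the same limit as compound 2.

For compound 4 the expected value in this assay is 400 nM, within a range from 100 nM to 3000 nM.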

Compound 4, half-maximal inhibitory concentration: > 100 nM
Compound 4 was reported as a limit; the forecaster's own chance of this, stated with the estimate: 70%; the middle value does not contradict the limit.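

Compound 2 and compound 4 are both reported as a limit of the assay and not as a number, so no step between them can be read: the limit of > 100 nM in this assay, at which 2 of the 4 values shown sit.

The compounds shown leave open whether moving bromine and carboxy around the benzyl ring changes inhibition in this assay at all, and what number any of the four compounds would give.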